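The source may hold more compounds than are shown below. What is called first, only, known or untested is meant among the compounds shown, and "the series" means these compounds.

Measured in a functional assay on RPMI8266 cells (Homo sapiens) for inhibition, read by sulforhodamine B assay, with a stated time of 48 h; on this read-out higher numbers stand for weaker inhibition of growth and lower numbers for stronger inhibition of growth:
compound 1, `Nc1cc(N)c2nc(-c3ccccc3)c(NCc3ccc(Cl)c(Cl)c3)nc2c1`, 3720 nM
compound 2, `COc1ccc(CNc2nc3cc(N)cc(N)c3nc2-c2ccccc2)cc1OC`, 7240 nM
compound 3, `Nc1cc(N)c2nc(-c3ccccc3)c(NCc3ccc(F)cc3)nc2c1`, 6310 nM

Compound 3 stands second highest of the three numbers in this assay; its nearest neighbour is compound 2 (a 1.1-fold lower number from compound 2 to compound 3 (0.06 log units; within the scatter)) and its furthest compound 1 (a 1.7-fold higher number from compound 1 to compound 3 (0.23 log units; within the scatter)), both within the scatter, as is a 1.9-fold higher number from compound 1 to compound 2 (0.29 log units; within the scatter).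

Compound 4, `COc1ccc(CNc2nc3cc(N)cc(N)c3nc2-c2ccccc2)cc1`, differs from compound 3 by methoxy in place of fluoro on an aromatic carbon. The change touches the same group varied in the steps above: a methoxy-bearing ring replacing a halogen-bearing one, as in the reverse of the step from compound 2 to compound 3, which stayed within the scatter. Among the measured compounds shown here, no step exceeded the scatter, so no change beyond it is expected in this assay, in either direction.

Compound 4 is estimated at 6300 nM, range 3000 nM to 13000 nM. The expected step is a 1.0-fold lower number from compound 3 to compound 4 (0.00 log units; within the scatter).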

Compound 4, concentration for total growth inhibition: 15800 nM
Compound 4: the middle estimate sits 2.5-fold (0.40 log units) below what was measured; measured number above the stated range.
By their numbers in this assay, from the lowest: compounds 1, 3 and 2 (each within the scatter of the next); then compound 4.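

In this assay this position first shows steps beyond the scatter: methoxy in place of fluoro gives (a 2.5-fold higher number from compound 3 to compound 4 (0.40 log units; beyond the scatter)), hydrogen in place of the second methoxy of compound 2 gives (a 2.2-fold higher number from compound 2 to compound 4 (0.34 log units; beyond the scatter)), and 4-methoxyphenyl in place of 3,4-dichlorophenyl gives (a 4.2-fold higher number from compound 1 to compound 4 (0.63 log units; beyond the scatter)). Among the compounds shown here, the single methoxy of compound 4 thus goes with weaker growth inhibition, whereas compound 2, with two methoxy groups, stays within the scatter of compound 1 and compound 3. No measurement at hand accounts for this.

Open, from the compounds shown here alone, is whether a hydroxy group or an amine in place of the methoxy would keep the number near that of compound 4 or return it towards that of compound 3.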